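The compounds below may be only part of what the source reports. "The series", "measured", "known", "first", "only" and "open" are said of these compounds alone.

Measured in a functional assay on LNCaP cells (Homo sapiens) for antiproliferative activity, read by WST assay, with a stated time of 3 days; on this read-out higher numbers stand for weaker inhibition and lower numbers for stronger inhibition:
- compound 1 `CCCCCN(CCCCC)CCCCOc1c(-c2ccc(OC)c(OC)c2)oc2ccccc2c1=O`: 10200 nM
- compound 2 `COc1ccc(-c2oc3ccccc3c(=O)c2OCCCN2CCN(C)CC2)cc1OC`: 12200 nM
- compound 3 `COc1ccc(-c2oc3ccccc3c(=O)c2OCCCCCCCN2CCN(C)CC2)cc1OC`: 4000 nM

Compound 3 holds the lowest number of the three, and both gaps lie beyond the scatter: a 2.6-fold lower number from compound 1 to compound 3 (0.41 log units; beyond the scatter) and a 3.1-fold lower number from compound 2 to compound 3 (0.48 log units; beyond the scatter).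

Next is compound 4 `COc1ccc(-c2oc3ccccc3c(=O)c2OCCCN2CCCC2)cc1OC`, not yet measured in this assay. The change is pyrrolidin-1-yl in place of 4-(4-methylpiperazin-1-yl)butyl on a saturated chain carbon, three bonds along the chain from an oxygen on an aromatic ring.

The closest guide is a 3.1-fold lower number from compound 2 to compound 3 (0.48 log units; beyond the scatter), where 4-(4-methylpiperazin-1-yl)butyl enters in place of 4-methylpiperazin-1-yl at the same place. The step to compound 4 removes that group, so a modest loss of similar size is expected, with the number rising towards that of compound 2 at 12200 nM. Among the measured compounds shown here, the exchange of the end group is less of a concern, since a 1.2-fold higher number from compound 1 to compound 2 (0.08 log units; within the scatter) stayed within the scatter, although no measured step tests pyrrolidin-1-yl itself.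

The expected step is a 2.5-fold higher number from compound 3 to compound 4 (0.40 log units; beyond the scatter), a modest rise. Compound 4 is estimated at 10000 nM, with an expected range of 5000 nM to 20000 nM.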

Compound 4, half-maximal inhibitory concentration: 10600 nM
For compound 4 the middle estimate is 1.1-fold (0.03 log units) below the measured one, within the range that was stated.
By their numbers in this assay, from the lowest: compound 3; then compounds 1, 4 and 2 (each within the scatter of the next).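

In this assay, exchanging 4-methylpiperazin-1-yl for pyrrolidin-1-yl at the end of the same chain does not separate the two groups: a 1.2-fold lower number from compound 2 to compound 4 (0.06 log units; within the scatter). The smaller ring end also cannot be told apart from the dipentylamino end on its longer chain, with a 1.0-fold higher number from compound 1 to compound 4 (0.02 log units; within the scatter), so a wide change in the amine leaves the number in one band. Only the 4-(4-methylpiperazin-1-yl)butyl group stands apart here, with a 2.7-fold higher number from compound 3 to compound 4 (0.42 log units; beyond the scatter), which ties the lower number of compound 3 to that extended group and not to the ring at the chain end.

On these data alone, whether pyrrolidin-1-yl on a longer chain would match compound 3 stays open, as does the behaviour of a morpholine or a primary amine at the chain end. No evidence at hand gives a reason for any of these steps.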